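Pyridin-2-yl Amide Replacing a Dimethylphenyl Amide

The source may report more compounds than this note shows. Statements on the series, on what has been measured and on what is new or still open speak of the compounds shown alone.

Compound 1: `Cc1cc(C(=O)NCN2CCC(c3cccc[n+]3[O-])CC2)ccc1F`; in a functional assay on HEK293 cells for agonist activity at D(4) dopamine receptor (Homo sapiens), read by FLIPR (on this read-out higher numbers stand for an effect only at larger amounts of compound and lower numbers for an effect already at smaller amounts), compound 1 gives 50 nM.
Compound 2: `C=Cc1cccc(C(=O)NCN2CCC(c3cccc[n+]3[O-])CC2)c1`; in this assay compound 2 gives 68 nM.
Compound 3: `Cc1cc(C)cc(C(=O)NCN2CCC(c3cccc[n+]3[O-])CC2)c1`; in this assay compound 3 gives 90 nM.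

Compound 3 holds the highest of the three numbers, yet its distance to compound 2 and to compound 1 lies within the scatter, so no order among the three can be read. The measured steps, a 1.4-fold higher number from compound 1 to compound 2 (0.13 log units; within the scatter), a 1.8-fold higher number from compound 1 to compound 3 (0.26 log units; within the scatter) and a 1.3-fold higher number from compound 2 to compound 3 (0.12 log units; within the scatter), each exchange one aryl group for another on the carbonyl carbon, and none moves beyond the scatter.

Compound 4 is `O=C(NCN1CCC(c2cccc[n+]2[O-])CC1)c1ccccn1`; it differs from compound 3 by pyridin-2-yl in place of 3,5-dimethylphenyl on a carbonyl carbon. Among the measured compounds shown here, no measured step exchanges a carbon-only ring for one with a hetero atom, so the measured steps bear on it only loosely: they show three exchanges of the aryl group on the carbonyl carbon, none with a step beyond the scatter. For compound 4 a step of a 1.7-fold higher number from compound 3 to compound 4 (0.22 log units; within the scatter) is therefore expected, with wide uncertainty. Compound 4 is estimated at 150 nM, within a range from 50 nM to 500 nM.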

Compound 4, half-maximal effective concentration: 3150 nM
For compound 4 the middle estimate is 21-fold (1.32 log units) below the measured one; measured number outside the range, above it.
By their numbers in this assay, from the lowest: compounds 1, 2 and 3 (each within the scatter of the next); then compound 4.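

In this assay, the aryl position on the carbonyl carbon tolerated three carbon-only rings with no step beyond the scatter, but it responds strongly to pyridin-2-yl: the exchange gives a 35-fold higher number from compound 3 to compound 4 (1.54 log units; beyond the scatter) and also a 46-fold higher number from compound 2 to compound 4 (1.67 log units; beyond the scatter) as well as a 63-fold higher number from compound 1 to compound 4 (1.80 log units; beyond the scatter) in the other two comparisons. The position is therefore not indifferent to the aryl group, and all three large steps bring in a ring with a hetero atom and a hydrogen-bond acceptor while also removing the substituents carried by each earlier ring. Nothing available gives a cause for these steps.

The compounds shown leave open whether the ring nitrogen or the lost substituents account for the change. Unsubstituted phenyl, pyridin-3-yl or a dimethylpyridin-2-yl group on the same carbonyl carbon would bear on that question.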